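A few compounds are considered here, and "the series" means these few. Any claim that something is new, unique, unknown or untested is made for them only; others in the source may bear on it.

Of the compounds shown here, three have been measured in an ADME assay on Huh-7 cells (Homo sapiens) for cytotoxicity; on this read-out lower numbers stand for higher toxicity in this test and higher numbers for lower toxicity in this test.
Compound 1, `Cc1ccccc1CNc1nn(-c2ccc(F)cc2F)cc1CNCCN1CCN(C)CC1`, gives > 20000 nM, which is a limit of the assay rather than a number.
Compound 2, `CN1CCN(CCNCc2cn(-c3ccc(F)cc3F)nc2-c2ccccc2)CC1`, gives > 20000 nM, again a limit.
Compound 3, `CN1CCN(CCNCc2cn(-c3ccc(F)cc3F)nc2-c2ccc(S(=O)(=O)N(C)C)cc2)CC1`, gives > 20000 nM, also a limit.

Compound 3 thus stands only at a limit, with no measured number of its own, and the same holds for the two compounds beside it. None of the steps between them can be read: the step that the two limits leave unreadable from compound 1 to compound 2, the step that the two limits leave unreadable from compound 1 to compound 3 and the step that the two limits leave unreadable from compound 2 to compound 3 all remain without a size, because of the limit of > 20000 nM in this assay, at which 3 of the 3 values shown sit.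

Compound 4, `Cc1ccccc1-c1nn(-c2ccc(F)cc2F)cc1CNCCN1CCN(C)CC1`, has not yet been measured. It differs from compound 3 in one place: 2-methylphenyl in place of 4-(dimethylsulfamoyl)phenyl on an aromatic carbon. The measured steps that touch this part of the shared core are the two that end at compound 3, and both are unreadable, so they give no direction and no size to carry over. What they do show is that three different groups at this position all left the value at the limit. No step beyond the scatter is therefore expected in this assay, and compound 4 is expected to remain at the limit as well. The estimated step from compound 3 to compound 4 is a step that the limit leaves unreadable from compound 3 to compound 4. Compound 4 is expected to give about 30000 nM in this assay, within a range from 15000 nM to 80000 nM.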

Compound 4, half-maximal cytotoxic concentration: > 20000 nM
Compound 4 gave a limit, no number (the forecaster's own chance of this, stated with the estimate: 85%); the middle value lies beyond the limit too.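

No step from compound 1, compound 2 or compound 3 to compound 4 can be read, because all four compounds stop at the same limit: the limit of > 20000 nM in this assay, at which 4 of the 4 values shown sit.

The compounds shown leave open whether any group at this position can bring the value in this assay to a measured number, and how far apart these four compounds truly lie.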